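Fluoro added to the 4-cyanophenyl ring

The source may hold more compounds than are shown below. What is called first, only, known or untested is meant among the compounds shown, and "the series" means these compounds.

In a toxicity assay on MT4 cells (Homo sapiens) for cytotoxicity, read by MTT assay (on this read-out higher numbers stand for lower toxicity in this test and lower numbers for higher toxicity in this test), compound 1 `Cc1cc(-c2ccccc2F)ccc1Oc1cc(N)nc(Nc2ccc(C#N)cc2)n1` gives 29500 nM and compound 2 `Cc1cc(-c2ccccc2C#N)ccc1Oc1cc(N)nc(Nc2ccc(C#N)cc2)n1` gives 28600 nM while compound 3 `Cc1cc(-c2ccc(C#N)cc2)ccc1Oc1cc(N)nc(Nc2ccc(C#N)cc2)n1` gives 10400 nM as the lowest of the three numbers. Compound 4 `Cc1cc(-c2ccc(C#N)c(F)c2)ccc1Oc1cc(N)nc(Nc2ccc(C#N)cc2)n1` takes fluoro in place of hydrogen on an aromatic carbon of compound 3, ortho to a cyano group and meta to a large group. The difference reads fluoro in place of hydrogen on an aromatic carbon and turns 4-cyanophenyl to 4-cyano-3-fluorophenyl.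

Cyano in place of fluoro gave a 1.0-fold lower number from compound 1 to compound 2 (0.01 log units; within the scatter) and stayed within the scatter. The two changes to 4-cyanophenyl gave a 2.8-fold lower number from compound 1 to compound 3 (0.45 log units; beyond the scatter) and a 2.8-fold lower number from compound 2 to compound 3 (0.44 log units; beyond the scatter) and were modest. Among the measured compounds shown here, no measured pair adds fluoro in place of hydrogen, so these steps serve only as a guide to size. From the compounds shown here alone, no step beyond the scatter is therefore expected in this assay and the direction stays open. The estimated step is a 1.2-fold higher number from compound 3 to compound 4 (0.06 log units; within the scatter) on this read-out. Compound 4 is estimated at 12000 nM with an expected range from 5500 nM to 26000 nM on the same read-out.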

Compound 4, half-maximal cytotoxic concentration: 6600 nM
Compound 4: the middle estimate sits 1.8-fold (0.26 log units) above what was measured; measured number inside the range.
By their numbers in this assay, from the lowest: compounds 4 and 3 (each within the scatter of the next); then compounds 2 and 1 (each within the scatter of the next).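

In this assay, fluoro in place of hydrogen on this aromatic carbon, ortho to a cyano group and meta to a large group, gives a step within the scatter (a 1.6-fold lower number from compound 3 to compound 4 (0.20 log units; within the scatter)), so the 4-cyanophenyl ring takes this single added atom with no readable shift. The 4-cyano-3-fluorophenyl group keeps the separation from the two 2-substituted rings, in place of 2-cyanophenyl (a 4.3-fold lower number from compound 2 to compound 4 (0.64 log units; beyond the scatter)) and in place of 2-fluorophenyl (a 4.5-fold lower number from compound 1 to compound 4 (0.65 log units; beyond the scatter)), both beyond the scatter and modest. Nothing available explains these numbers.

From the compounds shown here alone, what chloro, methoxy or an amine would give on this same carbon stays open. Also open, going by these compounds, is whether a group larger than fluoro here would stay within the scatter of compound 3.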